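The source may report more compounds than this note shows. Statements on the series, on what has been measured and on what is new or still open speak of the compounds shown alone.

Compound 1, `CCOC(=O)CCCCCOc1cccc(CN(C(=O)c2ccc(-c3cccc(N(C)C)c3)cc2)C(C)C)c1`: in an ADME assay on BJ cells (Homo sapiens) for cytotoxicity, read by CellTiter-Glo and resazurin assay, with a stated time of 72 h (a lower number here means that less compound is needed, a higher number that more compound is needed for the effect), compound 1 gives > 26000 nM, which is a limit of the assay.
Compound 2, `CCOC(=O)CCCCCOc1cccc(CN(C(=O)c2ccc(-c3ccc4ccccc4c3)cc2)C(C)C)c1`: in this assay compound 2 gives > 26000 nM, which is a limit of the assay.

Neither value is a real number; both sit at the limit of > 26000 nM in this assay, at which 2 of the 2 values shown sit, so compound 2 stands at that limit, and the step that the two limits leave unreadable from compound 1 to compound 2 cannot be read. Compound 3, `CCOC(=O)CCCCCOc1cccc(CN(C(=O)c2ccc(-c3ccncc3)cc2)C(C)C)c1`, has not yet been tested. It differs from compound 2 in one place: pyridin-4-yl in place of naphthalen-2-yl on an aromatic carbon. Going by the values given here, the only measured step that bears on this change is the one from compound 1 to compound 2, which was unreadable, so no measured step gives a size or a direction. With both measured values at the limit, the step that the limit leaves unreadable from compound 2 to compound 3 is expected to be none beyond the scatter in the readable sense, most likely ending again at the limit. Compound 3 is therefore estimated at 30000 nM, with a range from 12000 nM to 100000 nM.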

Compound 3, half-maximal effective concentration: > 26000 nM
Compound 3: no number, only a limit; the forecaster's own chance of this, stated with the estimate: 85%; the middle value is on the limit's open side.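

No step between compound 1, compound 2 and compound 3 can be read, since all three values are limits of the assay and not numbers: the limit of > 26000 nM in this assay, at which 3 of the 3 values shown sit.

On these data alone, it remains open how far apart these three compounds truly lie in this assay, and whether naphthalen-2-yl, pyridin-4-yl and 3-(dimethylamino)phenyl differ there at all.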